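From a Urea to an Amide at the Carbonyl Carbon

A few compounds are considered here, and "the series" means these few. Any claim that something is new, unique, unknown or untested is made for them only; others in the source may bear on it.

Compound 1, `O=C(Nc1cccc(-n2cc(-c3ccncc3)c(-c3cc(O)cc(Cl)c3)n2)c1)Nc1ccc(Cl)c(Cl)c1`: 94%
Compound 2, `COc1cc(Cl)cc(-c2nn(-c3cccc(NC(=O)Nc4ccc(Cl)c(Cl)c4)c3)cc2-c2ccncc2)c1`: 95%

In a functional assay on SF-268 cells (Homo sapiens) for inhibition, read by sulforhodamine B assay, with a stated time of 48 h, tested at 0.01 uM (on this read-out higher numbers stand for a weaker effect at the one concentration tested and lower numbers for a stronger effect), compound 1 gives 94% and compound 2 gives 95%. Compound 2 holds the higher of the two numbers, yet the step of a number 1 percentage points higher from compound 1 to compound 2 (within the scatter) lies within the scatter, so the two compounds cannot be told apart on this read-out. Compound 3, `COc1cc(Cl)cc(-c2nn(-c3cccc(NC(=O)c4cccc(C(F)(F)F)c4)c3)cc2-c2ccncc2)c1`, has not yet been measured. It differs from compound 2 in one place: 3-(trifluoromethyl)phenyl in place of (3,4-dichlorophenyl)amino on a carbonyl carbon. Among the compounds with values here, the only measured step, a number 1 percentage points higher from compound 1 to compound 2 (within the scatter), alters a different part of the shared core and says nothing about exchanging the (3,4-dichlorophenyl)amino group on the carbonyl carbon; no measured pair bears on this change. The expectation therefore rests on both measured compounds sitting close together. Compound 3 is expected to give 95%, between 82% and 105%, an estimated step of no change at the digits printed from compound 2 to compound 3 (within the scatter) that is not expected to exceed the scatter.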

Compound 3, a percentage reported as activity, at one concentration (the size of the read-out at that concentration, not a potency): 101%
Compound 3: middle estimate off by 6 percentage points, on the low side; the measured number falls inside the stated range.
By their numbers in this assay, from the lowest: compounds 1, 2 and 3 (each within the scatter of the next).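

Within the data shown here, the earlier pair changed only a methyl on an oxygen, so this is the first view of the group on the carbonyl carbon, and in this assay the exchange gives a number 6 percentage points higher from compound 2 to compound 3 (within the scatter). Replacing (3,4-dichlorophenyl)amino with 3-(trifluoromethyl)phenyl takes away the hydrogen-bond donor counted on the leaving group and turns the urea into an amide, yet this single-concentration read-out cannot tell the two compounds apart. No measurement at hand offers an explanation for this result.

As far as these compounds go, whether a morpholine ring or a butyl chain on the same carbonyl carbon would separate from these compounds remains open. So does how compound 2 and compound 3 would compare at higher concentrations, where a difference might emerge.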